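Adding a tert-butyl group to the strongest inhibitor so far

A few compounds are considered here, and "the series" means these few. Any claim that something is new, unique, unknown or untested is made for them only; others in the source may bear on it.

Measured so far in an assay on isolated protein for inhibition of 15-hydroxyprostaglandin dehydrogenase [NAD(+)] (Homo sapiens), read by fluorescence, with a stated time of 15 min; a higher number here means a weaker inhibitor, a lower number a stronger inhibitor:
compound 1 `Cc1cccc(-n2cnc3cc(C(=O)N4CC(C)CC(C)C4)ccc32)c1` gives 271 nM
compound 2 `Cc1cccc(-n2cnc3cc(C(=O)NC4CCCC4)ccc32)c1` gives 961 nM
compound 3 `O=C(c1ccc2c(c1)ncn2-c1ccccc1)N1CCCCC1` gives 22 nM

Compound 3 stands lowest of the three numbers in this assay, meaning it is the strongest inhibitor of the set; compound 1 is the nearest and compound 2 the furthest from it. Among the compounds with values here, the only single-point step in the set, a 3.5-fold higher number from compound 1 to compound 2 (0.55 log units; beyond the scatter), concerns the group on the carbonyl carbon and says nothing about the six-membered aromatic ring of carbon only.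

Compound 4 `CC(C)(C)c1cccc(-n2cnc3cc(C(=O)N4CCCCC4)ccc32)c1` is made from compound 3 by tert-butyl in place of hydrogen on an aromatic carbon. Within the data shown here, no measured step bears on this change. Compounds 1 and 2 carry a methyl on that ring and both give higher numbers than compound 3, but each also differs from compound 3 at the carbonyl carbon, so the two values alone cannot be read as the effect of the ring substituent.

With that in mind, a small loss is expected: the step of a 2.3-fold higher number from compound 3 to compound 4 (0.36 log units; beyond the scatter) is the estimate. Compound 4 is therefore expected to give about 50 nM, within a range from 12 nM to 250 nM.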

Compound 4, half-maximal inhibitory concentration: 171 nM
For compound 4 the middle estimate is 3.4-fold (0.53 log units) below the measured one; the range from low to high includes it.
By their numbers in this assay, from the lowest: compound 3; then compounds 4 and 1 (each within the scatter of the next); then compound 2.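

In this assay, tert-butyl in place of hydrogen on an aromatic carbon gives a 7.8-fold higher number from compound 3 to compound 4 (0.89 log units; beyond the scatter). Within the data shown here, this is the first step in the set that isolates a change on this six-membered aromatic ring of carbon only, with the rest of the molecule held the same, and it shows that adding 4 heavy atoms at this place, meta to a large group, weakens inhibition. No measurement available here accounts for the loss.

A single substituent cannot show whether the loss tracks the particular group or comes with any group at this carbon. A chlorine atom or a methoxy group at the same place on compound 3 would help separate these possibilities, and the other carbons of that ring remain unexplored in the compounds shown.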